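This account rests on a few compounds, and the source may have more. Where it says the series, first, only, none or still open, it means among the compounds named here.

Three close relatives of one shared core have been tested in a functional assay on PC-3 cells (Homo sapiens) for cytotoxicity, read by MTT assay, with a stated time of 72 h; on this read-out higher numbers stand for weaker inhibition and lower numbers for stronger inhibition. Compound 1 `O=S(=O)(c1ccc(F)cc1)c1nc2ccccc2nc1N1CCCC1` gives 12400 nM. Compound 2 `Cc1ccc(S(=O)(=O)c2nc3ccccc3nc2N2CCCC(O)C2)cc1` gives 5330 nM in this assay. Compound 3 `COc1ccc(S(=O)(=O)c2nc3ccccc3nc2N2CCCC(O)C2)cc1` gives 3410 nM in this assay, the lowest of the three numbers, although compound 2 sits within the scatter of it, so no real order between those two is claimed; the gap to compound 1, by contrast, is beyond the scatter. Among the measured compounds shown here, the only single change measured so far is the swap of methyl for methoxy, which gave a 1.6-fold lower number from compound 2 to compound 3 (0.19 log units; within the scatter), a step too small to count as a change.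

Compound 4 `O=S(=O)(c1ccc(F)cc1)c1nc2ccccc2nc1N1CCCC(O)C1` has not yet been measured. It differs from compound 3 by fluoro in place of methoxy on an aromatic carbon. Compound 1 carries the same fluoro group but differs from compound 3 in a second place as well, so the two values can only be set side by side, not read as a step. For the measured compounds named here, because the one measured single step, a 1.6-fold lower number from compound 2 to compound 3 (0.19 log units; within the scatter), lies within the scatter, and because compound 1 gives 12400 nM, a modest rise is expected, described as a 1.8-fold higher number from compound 3 to compound 4 (0.25 log units; within the scatter). Compound 4 is therefore estimated to give about 6000 nM in this assay, with a range from 2500 nM to 15000 nM.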

Compound 4, half-maximal inhibitory concentration: 2130 nM
For compound 4 the middle estimate is 2.8-fold (0.45 log units) above the measured one, outside the stated range (below it).
By their numbers in this assay, from the lowest: compounds 4, 3 and 2 (each within the scatter of the next, the first and the last beyond it); then compound 1.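

On the aromatic ring, para to a large group, fluoro in place of methoxy gives a 1.6-fold lower number from compound 3 to compound 4 (0.20 log units; within the scatter) in this assay, so these two groups cannot be told apart here, just as methyl and methoxy could not. Fluoro in place of methyl, however, gives a 2.5-fold lower number from compound 2 to compound 4 (0.40 log units; beyond the scatter), the first change at this position that exceeds the scatter, although its size is modest and compound 3, with its methoxy group, lies within the scatter of both neighbours. Among the compounds shown here, the result also gives the first reading at the other changing place: with the 4-fluorophenyl group held constant, 3-hydroxypiperidin-1-yl in place of pyrrolidin-1-yl gives a 5.8-fold lower number from compound 1 to compound 4 (0.77 log units; beyond the scatter), the largest single step in this small set.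

As far as these compounds go, the effect of an amine or a carboxylic acid on that aromatic carbon remains open, as does the effect of a longer chain at the place held by the 3-hydroxypiperidin-1-yl group. No supporting measurement accompanies these numbers, so the reason behind these steps remains unknown.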